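A few compounds are considered here, and "the series" means these few. Any claim that something is new, unique, unknown or untested is made for them only; others in the source may bear on it.

Working notes on the series. Within the data shown here, in a functional assay on A-431 cells (Homo sapiens) for inhibition, read by MTT assay, with a stated time of 72 h (on this read-out lower numbers stand for stronger inhibition and higher numbers for weaker inhibition), compound 2 `CC(C)=CC(=O)Nc1cccc(Oc2nc(Nc3cccc(C#N)c3)nc3ccsc23)c1` gives 28300 nM, the higher of the two numbers so far, although its gap to compound 1 is within the scatter. Compound 1 `C/C=C/C(=O)Nc1cccc(Oc2nc(Nc3cccc(C#N)c3)nc3ccsc23)c1` gives 20100 nM in this assay. Among the measured compounds shown here, the single measured step, a 1.4-fold higher number from compound 1 to compound 2 (0.15 log units; within the scatter), also alters only the unsaturated group on the carbonyl carbon and stays inside the scatter. Compound 3 `CC/C=C/C(=O)Nc1cccc(Oc2nc(Nc3cccc(C#N)c3)nc3ccsc23)c1` awaits measurement in this assay. It differs from compound 2 by but-1-en-1-yl in place of 2-methylprop-1-en-1-yl on a carbonyl carbon. For the measured compounds named here, the step from compound 1 to compound 2 is the only one bearing on this change, and since it lay within the scatter, no step beyond the scatter is expected in this assay in either direction. Compound 3 is therefore estimated at 23000 nM, with a range from 10000 nM to 50000 nM. This estimate corresponds to an expected step of a 1.2-fold lower number from compound 2 to compound 3 (0.09 log units; within the scatter).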

Compound 3, half-maximal inhibitory concentration: 36200 nM
Estimate against measurement, compound 3: 1.6-fold (0.20 log units) below, within the range that was stated.
By their numbers in this assay, from the lowest: compounds 1, 2 and 3 (each within the scatter of the next).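

On the carbonyl carbon, but-1-en-1-yl in place of 2-methylprop-1-en-1-yl gives a 1.3-fold higher number from compound 2 to compound 3 (0.11 log units; within the scatter) in this assay, so this rearrangement of the same count of carbon atoms, from a branched to an unbranched group, does not separate the two compounds. Methyl in place of hydrogen on the saturated chain carbon bound to a double-bonded chain carbon gives a 1.8-fold higher number from compound 1 to compound 3 (0.26 log units; within the scatter), so lengthening the unbranched group does not separate its compounds either, and all three groups at this position now read alike within the scatter. Nothing beyond these numbers bears on the result.

The compounds shown leave open whether an amine on the chain or a much longer chain on this carbonyl carbon would give a step beyond the scatter. They also leave open what a saturated butyl group would give in place of but-1-en-1-yl.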